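A few compounds are considered here, and "the series" means these few. Any claim that something is new, unique, unknown or untested is made for them only; others in the source may bear on it.

Working notes on a small urea series sharing one core and differing only in the substituent on one aromatic ring. In an assay on isolated protein for inhibition of serine/threonine-protein kinase TNNI3K (Homo sapiens) (a higher number here means a weaker inhibitor, a lower number a stronger inhibitor), compound 3 `CNc1cc(Oc2ccc(NC(=O)Nc3cccc(C(F)(F)F)c3)cc2)ncn1` gives 40 nM, the lowest number of the three measured; compound 2 `CNc1cc(Oc2ccc(NC(=O)Nc3cccc(C(F)F)c3)cc2)ncn1` gives 100 nM and compound 1 `CNc1cc(Oc2ccc(NC(=O)Nc3cccc(CF)c3)cc2)ncn1` gives 400 nM. The measured steps run a 4.0-fold lower number from compound 1 to compound 2 (0.60 log units; beyond the scatter), a 2.5-fold lower number from compound 2 to compound 3 (0.40 log units; beyond the scatter) and a 10-fold lower number from compound 1 to compound 3 (1.00 log units; beyond the scatter), each added fluorine going with a lower number. Compound 4 `CNc1cc(Oc2ccc(NC(=O)Nc3ccccc3)cc2)ncn1` differs from compound 3 by hydrogen in place of trifluoromethyl on an aromatic carbon. All three measured steps bear on this change, since compound 4 removes the entire group those steps built up; a step in the opposite direction, to a higher number, is expected, plausibly larger than a 10-fold lower number from compound 1 to compound 3 (1.00 log units; beyond the scatter). Compound 4 is therefore expected to give 1000 nM (range 300 nM to 4000 nM), a step of a 25-fold higher number from compound 3 to compound 4 (1.40 log units; beyond the scatter).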

Compound 4, half-maximal inhibitory concentration: 6300 nM
The estimate for compound 4 lay 6.3-fold (0.80 log units) below the measured number; measured number above the stated range.
By their numbers in this assay, from the lowest: compound 3; then compound 2; then compound 1; then compound 4.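

Removing the substituent altogether in this assay gives the largest steps in the series: a 160-fold higher number from compound 3 to compound 4 (2.20 log units; beyond the scatter) and a 63-fold higher number from compound 2 to compound 4 (1.80 log units; beyond the scatter) and a 16-fold higher number from compound 1 to compound 4 (1.20 log units; beyond the scatter). Even fluoromethyl therefore stands well apart from hydrogen on this aromatic carbon, and this last step exceeds the whole fluorine sequence of a 10-fold lower number from compound 1 to compound 3 (1.00 log units; beyond the scatter). No measurement bears on the reason for this gap. Open, on these data alone, is whether a plain methyl group or a chlorine atom at this place would track with hydrogen or with the fluorinated groups, and whether fluorine is needed at all.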